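The compounds below may be only part of what the source reports. "The series", "measured", "known", "first", "only" and "open" are said of these compounds alone.

Measured in a functional assay on KYSE-410 cells (Homo sapiens) for antiproliferative activity, read by MTT assay, with a stated time of 72 h; on this read-out higher numbers stand for weaker inhibition and lower numbers for stronger inhibition:

Compound 1 `COc1ccccc1NC(=O)c1cc(=O)[nH]c2cc(Br)ccc12`: > 20000 nM
Compound 2 `COc1ccc2c(C(=O)Nc3cc(F)cc(F)c3)cc(=O)[nH]c2n1`: > 20000 nM
Compound 3 `O=C(Nc1cccc(F)c1)c1cc(=O)[nH]c2cc(-c3ccccc3)ccc12`: > 20000 nM

None of these three results is a number; each is a limit of the assay. Compound 3 gives only a limit, > 20000 nM. It therefore stands with the other two, at the limit of > 20000 nM in this assay, at which 3 of the 3 values shown sit.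

Compound 4 `O=C(Nc1cccc(F)c1)c1cc(=O)[nH]c2cc(-c3ccsc3)ccc12` carries thiophen-3-yl in place of phenyl on an aromatic carbon. Going by the values given here, no measured pair shows what a single change does in this assay, so the only guide is the limit of compound 3, > 20000 nM. The expected step is a number no higher from compound 3 to compound 4 (the limit leaves the size open), with no change beyond the scatter in either direction. For compound 4 the estimated value is 20000 nM, with an expected range of 5000 nM to 30000 nM.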

Compound 4, half-maximal inhibitory concentration: 4300 nM
Compound 4: the middle estimate sits 4.7-fold (0.67 log units) above what was measured; the measured number lies below the stated range.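

In this assay, thiophen-3-yl in place of phenyl gives an at least 4.6-fold lower number from compound 3 to compound 4 (0.66 log units; beyond the scatter), which shows that a change at this position of the shared core can move the read-out. Going by these compounds, compound 3 gives only a limit, so the true size of this step stays open. Compound 4 is the only compound shown with a number, and the others remain at the limit: the limit of > 20000 nM in this assay, at which 3 of the 4 values shown sit.

The compounds shown leave open whether another five-membered ring, such as furan-3-yl, would give a similar number at this position. They also leave open what a smaller group here, such as an amine, would do.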